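A few compounds are considered here, and "the series" means these few. Any claim that something is new, unique, unknown or untested is made for them only; others in the source may bear on it.

Compound 1 `COc1cccc(CNc2ncnc3c2ncn3C2CCCCO2)c1` carries a 3-methoxyphenyl group on a saturated chain carbon bound to a nitrogen on an aromatic ring. In an ADME assay on MCF7 cells (Homo sapiens) for cytotoxicity, with a stated time of 72 h (on this read-out lower numbers stand for stronger inhibition and higher numbers for weaker inhibition), compound 1 gives 97000 nM. Compound 2 `COc1ccc(CNc2ncnc3c2ncn3C2CCCCO2)cc1` shares the same atoms joined differently, with 3-methoxyphenyl in place of 4-methoxyphenyl on a saturated chain carbon bound to a nitrogen on an aromatic ring marking how the two cores differ. In this assay compound 2 reaches only a limit, > 100000 nM, and not a number. The step of an at least 1.0-fold higher number from compound 1 to compound 2 (0.01 log units; that floor lies within the scatter) is therefore read only against that limit, which the limit of > 100000 nM in this assay, at which 1 of the 3 values shown sits, records.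

Compound 3 `COc1ccc(CNc2ncnc3c2ncn3C2CCCCO2)c(OC)c1` adds a methoxy group to compound 2, the change being (methoxy in place of hydrogen on an aromatic carbon). In this assay compound 3 also returns a limit, > 25000 nM, rather than a number. With both ends capped, the step that the two limits leave unreadable from compound 2 to compound 3 cannot be sized; the evidence here is the limit of > 25000 nM in this assay, at which 1 of the 3 values shown sits.

Compound 4 `COc1ccc(OC)c(CNc2ncnc3c2ncn3C2CCCCO2)c1` is related to compound 1 by the same kind of change, (methoxy in place of hydrogen on an aromatic carbon). The place differs in its printed wording: in compound 3 the entering methoxy is meta to a methoxy group, whereas in compound 4 it is para to a methoxy group, so the two changes are of the same kind but not the same.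

For compound 4 in this assay, the step from compound 1 is expected to be about a 1.0-fold higher number from compound 1 to compound 4 (0.01 log units; within the scatter), resting on compound 1 at 97000 nM and on the fact that the comparable step from compound 2 to compound 3 left no readable size. Compound 4 is thus estimated to give 100000 nM, plausibly between 40000 nM and 250000 nM, with a real chance that only a limit is reported.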

Compound 4, half-maximal inhibitory concentration: 25400 nM
Compound 4: middle estimate off by 3.9-fold (0.60 log units), on the high side; the whole stated range lies above it.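

In this assay, methoxy in place of hydrogen on compound 1 gives a 3.8-fold lower number from compound 1 to compound 4 (0.58 log units; beyond the scatter), so on this core the change, with the entering methoxy ortho to a large group and para to a methoxy group, moves the number beyond the scatter. The same kind of change on compound 2 puts the entering methoxy at a different place on the ring, and compound 3 returns only a limit and not a number, so that step, like every other step with a limit at one end, cannot be read: the limit of > 25000 nM in this assay, at which 1 of the 4 values shown sits. The series therefore holds one readable case of this change, which shows what it does on the core of compound 1 but does not show that the effect carries over to another core, either in direction or in size.

The compounds shown leave open whether the lower number belongs to the methoxy group itself or to the place it occupies, and whether the same place on compound 2 would behave alike. They also leave open whether a different group at that place, such as an amine, a carboxylic acid or a longer ether chain, would move the number in the same direction.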